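Adding trifluoromethoxy to compound 2

The compounds below may be only part of what the source reports. "The series", "measured", "known", "first", "only" and "open" are said of these compounds alone.

Compound 1 `CC(C)c1cccc(NC(=O)CCc2cccc3c2B(O)OC3)c1` gives 22000 nM
Compound 2 `O=C(CCc1cccc2c1B(O)OC2)Nc1cccc(-c2ccccc2)c1` gives 12000 nM
Compound 3 `O=C(CCc1cccc2c1B(O)OC2)Nc1cccc(-c2cccc(OC(F)(F)F)c2)c1` gives 9800 nM

In an ADME assay on WI-38 cells (Homo sapiens) for cytotoxicity, read by MTT assay, with a stated time of 72 h (a higher number here means a weaker inhibitor, a lower number a stronger inhibitor), compound 2 holds the middle of these three numbers, within the scatter of both other compounds. Compound 4 `O=C(CCc1cccc2c1B(O)OC2)Nc1cccc(-c2ccc(OC(F)(F)F)cc2)c1` departs from compound 2 by trifluoromethoxy in place of hydrogen on an aromatic carbon and thus carries trifluoromethoxy in place of hydrogen on an aromatic carbon, para to a large group. The same replacement, made at a different place, gave a 1.2-fold lower number from compound 2 to compound 3 (0.09 log units; within the scatter) and is the closest guide. The exchange of isopropyl for phenyl gave a 1.8-fold lower number from compound 1 to compound 2 (0.26 log units; within the scatter) and bears on this change only loosely. Neither step left the scatter, so the expected step is a 1.2-fold lower number from compound 2 to compound 4 (0.08 log units; within the scatter) and thus none beyond the scatter. Compound 4 is expected at 10000 nM in an estimated range from 5500 nM to 18000 nM in this measurement.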

Compound 4, half-maximal inhibitory concentration: 25000 nM
The estimate for compound 4 lay 2.5-fold (0.40 log units) below the measured number, and the stated range ends below it.
By their numbers in this assay, from the lowest: compounds 3, 2, 1 and 4 (each within the scatter of the next, the first and the last beyond it).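

In this assay, among the compounds shown here, trifluoromethoxy in place of hydrogen, para to a large group, gave a 2.1-fold higher number from compound 2 to compound 4 (0.32 log units; beyond the scatter) and so moved beyond the scatter, which no earlier step had done. The same replacement at a different place left compound 3 within the scatter of compound 2, so in this series the outcome depends on where the group stands. Nothing measured here accounts for this difference. Going by these compounds, whether fluorine, methoxy or an amine at this place would shift the number as well remains open.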